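The source may hold more compounds than are shown below. What is called first, only, known or untested is meant among the compounds shown, and "the series" means these compounds.

Compound 2 `CN(CC1CC1)C(=O)c1cccc(-c2cccc(-n3ncc(C(=O)O)c3C3CC3)c2)c1F` is one of two compounds with a recorded value in an assay on BEAS-2B cells for activation of nuclear factor erythroid 2-related factor 2 (Homo sapiens), read by MTT assay, with a stated time of 48 h; a lower number here means that less compound is needed, a higher number that more compound is needed for the effect. In this assay compound 2 gives 2200 nM, the higher of the two numbers, while compound 1 `CN(C)C(=O)[C@H]1CCC[C@@H](c2cccc(-n3ncc(C(=O)O)c3C3CC3)c2)C1` gives 1700 nM; the gap between them lies within the scatter, so the two cannot be told apart on these numbers. Compound 3 `O=C(O)c1cnn(-c2cccc(-c3cccc(C(=O)N4CCCC5(CCCC5)C4)c3F)c2)c1C1CC1` has not yet been measured. It differs from compound 2 in a single place: a group of 10 heavy atoms (9 carbon, 1 nitrogen; one five-membered non-aromatic ring of carbon only, one six-membered non-aromatic ring with 1 hetero atom) in place of a group of 6 heavy atoms (5 carbon, 1 nitrogen; one three-membered non-aromatic ring of carbon only), on a carbonyl carbon. Going by the values given here, no measured pair shows what a change of this kind on the carbonyl carbon does in this assay, so there is nothing to set the size of the step by. The step from compound 2 to compound 3 is expected to be no change at the digits printed from compound 2 to compound 3 (within the scatter), with no direction beyond the scatter favoured. Compound 3 is therefore estimated at 2200 nM, with a range from 700 nM to 7000 nM.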

Compound 3, half-maximal effective concentration in the nuclear factor erythroid 2-related factor 2 assay: 3700 nM
Compound 3: middle estimate off by 1.7-fold (0.23 log units), on the low side; the range from low to high includes it.
By their numbers in the nuclear factor erythroid 2-related factor 2 assay, from the lowest: compounds 1, 2 and 3 (each within the scatter of the next, the first and the last beyond it).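

In the nuclear factor erythroid 2-related factor 2 assay, the exchange on the carbonyl carbon gives a 1.7-fold higher number from compound 2 to compound 3 (0.23 log units; within the scatter), so this place accepts the larger two-ring group without a difference that can be told from the scatter. In a physicochemical assay for lipophilicity, read by HPLC, at pH 2 (a higher number here means a more lipophilic compound, a lower number a more polar compound), compound 2 gives 2.2 and compound 3 gives 3.7. The same exchange gives a clear difference in lipophilicity, as read in the physicochemical assay: the measured distribution coefficient of compound 2, 2.2, and of compound 3, 3.7, a number 1.50 log units higher (beyond the scatter) In this one pair, then, a step beyond the scatter in the physicochemical assay stands beside a step within the scatter in the nuclear factor erythroid 2-related factor 2 assay.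

From the compounds shown here alone, it remains open how a morpholine ring or a hydroxyl group on this part of the amide would fare in the nuclear factor erythroid 2-related factor 2 assay. Going by these compounds, it is also open whether any group on this carbonyl carbon can move the number in the nuclear factor erythroid 2-related factor 2 assay beyond the scatter in either direction.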